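A para-methoxy variant of an inactive diaryl ether series

A few compounds are considered here, and "the series" means these few. Any claim that something is new, unique, unknown or untested is made for them only; others in the source may bear on it.

Measured compounds:
compound 1, `O=C(O)C[C@@H]1CCCN1c1ccc(Oc2ccccc2)cc1`, with > 16000 nM;
compound 2, `CCOc1ccccc1Oc1ccc(N2CCC[C@H]2CC(=O)O)cc1`, with > 33000 nM;
compound 3, `CC(C)(C)c1ccccc1Oc1ccc(N2CCC[C@H]2CC(=O)O)cc1`, with > 17000 nM.

All three values come from a functional assay on cells for agonist activity at Free fatty acid receptor 1 (Mus musculus), read by FLIPR and calcium flux, with a stated time of 100 s; a lower number here means that less compound is needed, a higher number that more compound is needed for the effect. For compound 1 the value is a limit of the assay, not a number. The same holds for compound 2, whose value is also a limit. Compound 3 likewise gives only a limit. Compound 1 therefore stands at the limit of > 16000 nM in this assay, at which 1 of the 3 values shown sits, with the other two compounds at the limit of > 17000 nM in this assay, at which 1 of the 3 values shown sits, and (the limit of > 33000 nM in this assay, at which 1 of the 3 values shown sits); none of the three has a readable number.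

Compound 4, `COc1ccc(Oc2ccc(N3CCC[C@H]3CC(=O)O)cc2)cc1`, differs from compound 1 by methoxy in place of hydrogen on an aromatic carbon. The measured steps that bear on a substituent entering the outer ring are a step that the two limits leave unreadable from compound 1 to compound 2 and a step that the two limits leave unreadable from compound 1 to compound 3; both start and end at limits, so their size cannot be read. The comparison a step that the two limits leave unreadable from compound 2 to compound 3 is equally unreadable. Within the data shown here, with every measured compound at a limit, no step of any size or direction can be inferred from the data in this assay. Compound 4 is therefore expected to remain near the limits, with an estimated value of 20000 nM, in the range 5000 nM to 80000 nM. The expected step is estimated as a step that the limit leaves unreadable from compound 1 to compound 4.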

Compound 4, half-maximal effective concentration: > 33000 nM
Compound 4 gave a limit, no number; the forecaster's own chance of this, stated with the estimate: 70%; middle value at least 1.6-fold (0.21 log units) from the limit.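

In this assay compound 4 gives > 33000 nM, which is a limit of the assay and not a number. Among these compounds, compound 1 also stands at a limit, so no step from compound 1 to compound 4 can be read. The compounds shown leave open whether methoxy, ethoxy or tert-butyl in place of hydrogen changes the concentration needed at all.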